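The compounds below may be only part of what the source reports. "The series", "measured", "known", "first", "only" and "open" are said of these compounds alone.

Measured compounds:
compound 1 `COC(=O)/C=C/c1cccc(N(Cc2ccc(/C=C/c3ccccc3F)cc2)C(=O)NC(C)C)c1` — 431 nM
compound 2 `COC(=O)/C=C/c1cccc(N(Cc2ccc(/C=C/c3c(C)cc(C)cc3C)cc2)C(=O)NC(C)C)c1` — 431 nM
compound 3 `COC(=O)/C=C/c1cccc(N(Cc2ccc(/C=C/c3ccc(F)cc3)cc2)C(=O)C(C)C)c1` — 120 nM

In an assay on isolated protein with Bile acid receptor (Homo sapiens) as the target (a lower number here means that less compound is needed, a higher number that more compound is needed for the effect), compound 3 holds the lowest number of the three; compound 1 and compound 2 both sit well beyond the scatter above it. Compound 4 `COC(=O)/C=C/c1cccc(N(Cc2ccc(/C=C/c3ccc(F)cc3)cc2)C(=O)NC(C)C)c1` is not yet measured. It differs from compound 3 by isopropylamino in place of isopropyl on a carbonyl carbon. For the measured compounds named here, the only single-change step recorded, no change at the digits printed from compound 1 to compound 2 (within the scatter), concerns the aryl group and does not bear on this change. Going by the values given here, no pair in the set isolates the isopropyl-to-isopropylamino change, so the expectation rests on the two carbamoyl compounds, compound 1 and compound 2, both giving higher numbers than compound 3. A rise is therefore expected for compound 4, a 2.9-fold higher number from compound 3 to compound 4 (0.46 log units; beyond the scatter), to an estimated 350 nM (range 120 nM to 1000 nM).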

Compound 4, half-maximal effective concentration: 348 nM
Compound 4: middle estimate off by 1.0-fold (0.00 log units), on the high side; the measured number falls inside the stated range.
By their numbers in this assay, from the lowest: compound 3; then compounds 4, 1 and 2 (each within the scatter of the next).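

In this assay, for the compounds shown here, isopropylamino in place of isopropyl on a carbonyl carbon gives a 2.9-fold higher number from compound 3 to compound 4 (0.46 log units; beyond the scatter) in the only pair that isolates this change. With isopropylcarbamoyl held constant, 4-fluorophenyl in place of 2,4,6-trimethylphenyl gives a 1.2-fold lower number from compound 2 to compound 4 (0.09 log units; within the scatter) and 4-fluorophenyl in place of 2-fluorophenyl gives a 1.2-fold lower number from compound 1 to compound 4 (0.09 log units; within the scatter). No supporting data accompany these results to account for the rise at this carbonyl carbon. Going by these compounds, it remains open whether the rise holds with 2-fluorophenyl or 2,4,6-trimethylphenyl in place of 4-fluorophenyl. On these data alone, the effect of a methylamino or tert-butylamino group on the same carbonyl carbon also remains open.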